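The source may hold more compounds than are shown below. What is called first, only, known or untested is meant among the compounds shown, and "the series" means these compounds.

Measured so far:

Compound 1 `Cc1ccc(Cn2cc(CSC(=S)N3CCN(C(N)=O)CC3)nn2)cc1`: in a functional assay on MCF7 cells (Homo sapiens) for cytotoxicity, read by MTT assay, with a stated time of 72 h (a lower number here means a stronger inhibitor, a higher number a weaker inhibitor), compound 1 gives only a limit of the assay, > 128000 nM.

Compound 2 `CCNC(=O)N1CCN(C(=S)SCc2cn(Cc3ccc(C)cc3)nn2)CC1`: in this assay compound 2 also gives only a limit, > 128000 nM.

Compound 3 `COc1cc(Cn2cc(CSC(=S)N3CCN(C(N)=O)CC3)nn2)cc(OC)c1OC`: in this assay compound 3 likewise gives only a limit, > 128000 nM.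

Compound 1 and compound 2 differ in one place: ethyl in place of hydrogen on an amide-type nitrogen. The step this change makes is a step that the two limits leave unreadable from compound 1 to compound 2, and its size cannot be read: both values are limits, which the limit of > 128000 nM in this assay, at which 3 of the 3 values shown sit, records. Compound 3 carries a different core; the difference between the core of compound 1 and the core of compound 3 is not broken down here.

Compound 4 `CCNC(=O)N1CCN(C(=S)SCc2cn(Cc3cc(OC)c(OC)c(OC)c3)nn2)CC1` has not yet been measured in this assay. It differs from compound 3 by the same change made between compound 1 and compound 2: ethyl in place of hydrogen on an amide-type nitrogen. The place is the same in both pairs, so this is the same change, not merely the same kind. Compound 3 sits at the limit, and ethyl in place of hydrogen on an amide-type nitrogen did not move compound 2 off that limit either. Compound 4 is therefore expected to stay at the limit, a step that the limit leaves unreadable from compound 3 to compound 4. The estimate for compound 4 in this assay is 150000 nM.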

Compound 4, half-maximal inhibitory concentration: > 128000 nM
Compound 4: a limit, no number (the forecaster's own chance of this, stated with the estimate: 85%); the middle value is on the limit's open side.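

In this assay compound 3 and compound 4 both give only a limit, so no step can be read from swapping hydrogen for ethyl on the amide-type nitrogen, and the same holds for compound 1 and compound 2: the limit of > 128000 nM in this assay, at which 4 of the 4 values shown sit. The compounds shown leave open how strong any of the four is and whether this change has any effect.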